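The source may report more compounds than this note shows. Statements on the series, on what has been measured and on what is new or still open speak of the compounds shown alone.

Working notes on the series. Going by the values given here, in a functional assay on aorta with Alpha-1D adrenergic receptor (Rattus norvegicus) as the target (a lower number here means that less compound is needed, a higher number that more compound is needed for the effect), compound 2 `O=c1c2ccccc2c(Cc2ccc(Cl)cc2)nn1-c1ccc([N+](=O)[O-])cc1` gives 29000 nM, the only number among the three values shown. Compound 1 `CC(C)(C)n1nc(Cc2ccc(Cl)cc2)c2ccccc2c1=O` reaches only a limit of the assay, > 100000 nM. Compound 3 `CSc1ccc(Cc2nn(-c3ccc([N+](=O)[O-])cc3)c(=O)c3ccccc23)cc1` likewise gives only a limit, > 100000 nM; two of three values therefore sit at the limit of > 100000 nM in this assay, at which 2 of the 3 values shown sit. Among the compounds with values here, the one measured step that bears on the next change is an at least 3.4-fold lower number from compound 1 to compound 2 (0.53 log units; beyond the scatter), where the aryl group on the aromatic nitrogen brought the value into range. Compound 4 `C=CCn1nc(Cc2ccc(Cl)cc2)c2ccccc2c1=O` reverses that direction: allyl in place of 4-nitrophenyl on an aromatic nitrogen. An allyl group, like tert-butyl in compound 1, carries no ring, so a higher number is expected, a 3.4-fold higher number from compound 2 to compound 4 (0.54 log units; beyond the scatter), quite possibly back to a limit. Compound 4 is estimated at 100000 nM, within 40000 nM to 300000 nM.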

Compound 4, half-maximal effective concentration: 2600 nM
Estimate against measurement, compound 4: 38-fold (1.59 log units) above, outside the stated range (below it).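

In this assay, an aromatic ring on this nitrogen is not what brings the value into range: replacing 4-nitrophenyl with allyl gives an 11-fold lower number from compound 2 to compound 4 (1.05 log units; beyond the scatter). Two groups without a ring also differ widely at this position, with an at least 38-fold lower number from compound 1 to compound 4 (1.58 log units; beyond the scatter). That second step is only a bound, as compound 1 stands at a limit of the assay: the limit of > 100000 nM in this assay, at which 2 of the 4 values shown sit.

The compounds shown leave open whether a saturated propyl group or a longer chain on this nitrogen keeps the value of compound 4. They also leave open whether methylsulfanyl in place of chloro costs as much with allyl on the nitrogen as with 4-nitrophenyl.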